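A few compounds are considered here, and "the series" means these few. Any claim that something is new, unique, unknown or untested is made for them only; others in the source may bear on it.

Measured compounds:
- compound 1 `Cc1ccc(S(=O)(=O)Oc2ccc3c(c2C)[C@H](Cn2cc(-c4ccccn4)nn2)[C@@]24CC(=O)[C@@](C)(CC[C@@H]32)C4)cc1`: > 20000 nM
- compound 2 `C=C1C[C@]23C[C@@]1(O)CC[C@H]2c1ccc(OS(=O)(=O)c2ccc(C)cc2)c(C)c1[C@@H]3Cn1cc(-c2ccc(OC)cc2)nn1`: > 20000 nM
- compound 3 `C=C1C[C@]23C[C@@]1(O)CC[C@H]2c1ccc(O)c(C)c1[C@@H]3Cn1cc(-c2ccc(OC)cc2)nn1`: > 20000 nM

In a functional assay on SW480 cells (Homo sapiens) for cytotoxicity, read by MTT assay, with a stated time of 4 days (on this read-out higher numbers stand for weaker inhibition and lower numbers for stronger inhibition), compound 2 gives > 20000 nM, which is a limit of the assay and not a number. The same holds for compound 1, whose value > 20000 nM is a limit. Compound 3 likewise sits at a limit, > 20000 nM. So every value shown sits at the limit of > 20000 nM in this assay, at which 3 of the 3 values shown sit, and the series offers no readable number anywhere.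

Among the measured compounds shown here, the one step between neighbours that differ in a single place, a step that the two limits leave unreadable from compound 2 to compound 3, cannot be read because both ends are limits. Compound 1 shares the pyridin-2-yl group with the compound under study but rests on a different core, so nothing beyond its limit can be taken from it.

The compound under study, compound 4 `C=C1C[C@]23C[C@@]1(O)CC[C@H]2c1ccc(OS(=O)(=O)c2ccc(C)cc2)c(C)c1[C@@H]3Cn1cc(-c2ccccn2)nn1`, differs from compound 2 by pyridin-2-yl in place of 4-methoxyphenyl on an aromatic carbon. For the measured compounds named here, no measured step bears on this exchange. With all three values at the limit, the expected step in this assay is none that the assay could show; the step is expected to be a step that the limit leaves unreadable from compound 2 to compound 4. Compound 4 is therefore expected to give 30000 nM in this assay, with a range of 12000 nM to 100000 nM, most likely reported again as a limit.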

Compound 4, half-maximal inhibitory concentration: > 20000 nM
Compound 4 gave a limit, no number (the forecaster's own chance of this, stated with the estimate: 85%); the middle value does not contradict the limit.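

No new step can be read between compound 2 and compound 4, since both values are limits and not numbers: the limit of > 20000 nM in this assay, at which 4 of the 4 values shown sit.

The compounds shown leave open whether pyridin-2-yl and 4-methoxyphenyl differ at all on the shared core, and what structure would give a readable number in this assay.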